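Herbicidal thiourea analogues: pyrimidine swap on compound 1

A few compounds are considered here, and "the series" means these few. Any claim that something is new, unique, unknown or untested is made for them only; others in the source may bear on it.

Measured compounds:
compound 1 `COc1cc(Cl)nc(NC(=S)NC(=O)c2c(-c3ccc(Cl)cc3Cl)noc2C)n1`, 53.2%
compound 2 `COc1cc(SC)nc2n/c(=N/C(=O)c3c(-c4ccc(Cl)cc4Cl)noc3C)sn12`, 68.3%

In a functional assay on the whole organism for inhibition, with Chenopodium ficifolium as the target, with a stated time of 72 h, tested at 100 mg/L (on this read-out lower numbers stand for less inhibition of growth and higher numbers for more inhibition of growth at the one concentration tested), compound 1 gives 53.2%, the lower of the two numbers, with compound 2 higher by a margin beyond the usual scatter. Compound 3 `Cc1cc(C)nc(NC(=S)NC(=O)c2c(-c3ccc(Cl)cc3Cl)noc2C)n1` is not yet measured; it differs from compound 1 by one change: 4,6-dimethylpyrimidin-2-yl in place of 4-chloro-6-methoxypyrimidin-2-yl on an amide-type nitrogen. Within the data shown here, no measured pair shows what such a swap does, so the expected step of a number 3.2 percentage points lower from compound 1 to compound 3 (within the scatter) is small, likely within the scatter, in no firm direction. Compound 3 is therefore estimated at 50%, in the range 30% to 70%.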

Compound 3, percent growth inhibition at one concentration: 65.4%
Compound 3: middle estimate off by 15.4 percentage points, on the low side; low and high end bracket the measured number.
By their numbers in this assay, from the lowest: compound 1; then compounds 3 and 2 (each within the scatter of the next).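

In this assay, replacing 4-chloro-6-methoxypyrimidin-2-yl with 4,6-dimethylpyrimidin-2-yl on the amide-type nitrogen gives a number 12.2 percentage points higher from compound 1 to compound 3 (beyond the scatter) and shows that this position responds to a change of pyrimidine substituents. Compound 3 also shows that growth inhibition at this level does not depend on keeping the chlorine or the methoxy group. Nothing available explains the rise. The swap changes both pyrimidine substituents at once, leaving open which replacement carries the step. From the compounds shown here alone, how a pyrimidine bearing an amine or two methoxy groups would behave also remains open.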